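A few compounds are considered here, and "the series" means these few. Any claim that something is new, unique, unknown or untested is made for them only; others in the source may bear on it.

Measured so far in a functional assay on MGC-803 cells (Homo sapiens) for inhibition, read by MTT assay, with a stated time of 48 h; on this read-out lower numbers stand for stronger inhibition and higher numbers for weaker inhibition:
compound 1 `COc1ccc(CNc2cc(OC)c(OC)c(OC)c2)cc1Cl`: 46200 nM
compound 2 `COc1ccc(CN(C(=O)C=C(C)C)c2cc(OC)c(OC)c(OC)c2)cc1O`: 320 nM

Compound 2 gives the lowest number of the two; compound 1, differing at more than one place, sits far higher, beyond the scatter. Among the compounds with values here, no single-change step between measured compounds is available to calibrate the next move.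

Compound 3 `COc1ccc(CN(C(=O)/C=C/CBr)c2cc(OC)c(OC)c(OC)c2)cc1O` carries the change (3-bromoprop-1-en-1-yl in place of 2-methylprop-1-en-1-yl on a carbonyl carbon).

With only these two points, the step from compound 2 to compound 3 is expected to be small, at most a modest decrease, a 1.6-fold lower number from compound 2 to compound 3 (0.20 log units; within the scatter). Compound 3 is estimated at 200 nM, with a range from 60 nM to 700 nM.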

Compound 3, half-maximal inhibitory concentration: 71 nM
Compound 3: the middle estimate sits 2.8-fold (0.45 log units) above what was measured, within the range that was stated.
By their numbers in this assay, from the lowest: compound 3; then compound 2; then compound 1.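

In this assay the group on the carbonyl carbon bonded to the amide-type nitrogen proves able to shift the number: 3-bromoprop-1-en-1-yl in place of 2-methylprop-1-en-1-yl gives a 4.5-fold lower number from compound 2 to compound 3 (0.65 log units; beyond the scatter), beyond the scatter. The two groups have the same heavy-atom count and each has one double bond, so the step comes with no change in these counts. No measured evidence bears on the reason for the step.

Going by these compounds, it remains open whether the bromine itself carries the step. A chlorine or an amine in its place, or a longer chain at this carbonyl carbon, would test this.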